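Adding a Methoxy Group to Compound 2

This account rests on a few compounds, and the source may have more. Where it says the series, first, only, none or still open, it means among the compounds named here.

Going by the values given here, compound 2 `COc1ccc(-c2cc(/C=C/C(=O)c3ccc(Cl)cc3)nc3cc(-c4ccccc4)nn23)cc1OC` stands second highest of the three numbers measured so far. In an ADME assay on HEK293 cells (Homo sapiens) for antiproliferative activity, read by MTT assay, with a stated time of 24 h (on this read-out lower numbers stand for stronger inhibition and higher numbers for weaker inhibition), compound 2 gives 44100 nM; compound 1 `COc1ccc(C(=O)/C=C/c2cc(-c3ccc(OC)c(OC)c3)n3nc(-c4ccccc4)cc3n2)cc1OC` gives 32500 nM and compound 3 `COc1ccc(-c2cc(/C=C/C(=O)c3ccc(C)cc3)nc3cc(-c4ccccc4)nn23)cc1OC` gives 62600 nM. The three steps among them, a 1.4-fold higher number from compound 1 to compound 2 (0.13 log units; within the scatter), a 1.9-fold higher number from compound 1 to compound 3 (0.28 log units; within the scatter) and a 1.4-fold higher number from compound 2 to compound 3 (0.15 log units; within the scatter), all stay within the scatter, and all concern the group on the carbonyl carbon. Compound 4 `COc1cc(-c2cc(/C=C/C(=O)c3ccc(Cl)cc3)nc3cc(-c4ccccc4)nn23)cc(OC)c1OC` differs from compound 2 elsewhere: methoxy in place of hydrogen on an aromatic carbon. Among the compounds with values here, no measured step touches that ring, so the only guidance is how little the series has moved, and no step beyond the scatter is expected, giving a 1.0-fold lower number from compound 2 to compound 4 (0.00 log units; within the scatter). Compound 4 is therefore estimated at 44000 nM, within 18000 nM to 105000 nM.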

Compound 4, half-maximal inhibitory concentration: >= 100000 nM
Compound 4: no number, only a limit; the forecaster's own chance of this, stated with the estimate: 10%; middle value at least 2.2-fold (0.35 log units) away from the limit.
By their numbers in this assay, from the lowest: compounds 1, 2 and 3 (each within the scatter of the next). At a limit, above all of these: compound 4.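

In this assay compound 4 gives >= 100000 nM, which is a limit and not a number: the limit of >= 100000 nM in this assay, at which 1 of the 4 values shown sits.

Even so, the change to 3,4,5-trimethoxyphenyl gives an at least 2.2-fold higher number from compound 2 to compound 4 (0.35 log units; beyond the scatter), the only step shown that lies beyond the scatter. Thus, in this one pair, a change on this ring moved the read-out, whereas the changes on the carbonyl carbon stayed within the scatter.

From the compounds shown here alone, how far compound 4 lies past its limit stays open. So does whether a hydroxy group, an amine or a longer alkoxy chain on this aromatic carbon would give a similar step.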